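Working Notes: Methyl to Pyridylethenyl on the Shared Core

The compounds below may be only part of what the source reports. "The series", "measured", "known", "first", "only" and "open" are said of these compounds alone.

Cytotoxicity in an ADME assay on BEAS-2B cells (Homo sapiens) for inhibition, read by MTT assay, with a stated time of 24 h (a lower number here means a stronger inhibitor, a higher number a weaker inhibitor), is the only read-out shown. Compound 1 `COc1ccc(NC(=O)Cn2c(=O)c(/C=C\c3ccncc3)nc3ccccc32)cc1OC` gives in this assay only the assay limit > 100000 nM. Compound 2 `Cc1nc2ccccc2nc1OCC(=O)Nc1ccc(Cl)cc1`, with a methyl on the shared core, likewise returns only a limit in this assay, > 100000 nM. Both values shown are therefore limits (the limit of > 100000 nM in this assay, at which 2 of the 2 values shown sit), so compound 2 stands at the edge of what this assay can resolve, with no number to separate it from compound 1.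

Compound 3 `O=C(COc1nc2ccccc2nc1/C=C\c1ccncc1)Nc1ccc(Cl)cc1` carries 2-(pyridin-4-yl)ethenyl in place of methyl on an aromatic carbon. Within the data shown here, no measured pair shows this change. Among the measured compounds shown here, the only guide is compound 1, which already bears the same 2-(pyridin-4-yl)ethenyl group and sits at the limit > 100000 nM. No step beyond the scatter is expected in this assay, in either direction. Compound 3 is expected at 100000 nM, range 30000 nM to 300000 nM, most likely reported again only as a limit. The expected step from compound 2 to compound 3 is a number no higher from compound 2 to compound 3 (the limit leaves the size open).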

Compound 3, half-maximal inhibitory concentration: > 100000 nM
Compound 3: no number, only a limit; the forecaster's own chance of this, stated with the estimate: 75%; the middle value sits exactly at the limit.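

In this assay compound 2 and compound 3 both return only a limit, so no step can be read between them: the limit of > 100000 nM in this assay, at which 3 of the 3 values shown sit.

The compounds shown leave open whether 2-(pyridin-4-yl)ethenyl in place of methyl changes this read-out at all.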